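The source may report more compounds than this note shows. Statements on the series, on what has been measured and on what is new or still open speak of the compounds shown alone.

Three compounds share one core and differ only in a single group on an aromatic carbon. In a functional assay on Bel-7402 cells (Homo sapiens) for cytotoxicity, read by MTT assay, with a stated time of 48 h (on this read-out higher numbers stand for weaker inhibition and lower numbers for stronger inhibition), compound 1 `CCn1cc(-c2nc3ccccc3[nH]2)c(=O)c2cc(F)c(N3CCNC(C)C3)c(F)c21`, which carries 1H-benzimidazol-2-yl, gives 30200 nM. Compound 2 `CCn1cc(-c2nc3ccccc3o2)c(=O)c2cc(F)c(N3CCNC(C)C3)c(F)c21`, with 1,3-benzoxazol-2-yl, gives 5700 nM, and compound 3 `CCn1cc(-c2nc3ccccc3s2)c(=O)c2cc(F)c(N3CCNC(C)C3)c(F)c21`, with 1,3-benzothiazol-2-yl, gives 15000 nM. Compound 1 stands at the weak end of this set, level with compound 3, as a 2.0-fold lower number from compound 1 to compound 3 (0.30 log units; within the scatter) does not separate the two. Compound 2 is the most potent of the three, set apart by a 5.3-fold lower number from compound 1 to compound 2 (0.72 log units; beyond the scatter) and by a 2.6-fold higher number from compound 2 to compound 3 (0.42 log units; beyond the scatter).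

Compound 4 `CCn1cc(-c2nc3ccc([N+](=O)[O-])cc3[nH]2)c(=O)c2cc(F)c(N3CCNC(C)C3)c(F)c21` has not yet been measured. It keeps the 1H-benzimidazol-2-yl of compound 1, and the difference is nitro in place of hydrogen on an aromatic carbon, with nitro in place of hydrogen on an aromatic carbon of a six-membered aromatic ring of carbon only. Within the data shown here, none of the measured steps adds a nitro. They exchange the whole group, so they serve only as a rough guide to size, and that guide is a modest step at most. The expectation of a lower number rests only on compound 1 giving 30200 nM at the weak end of the set, and the direction remains uncertain. An estimated 2.0-fold lower number from compound 1 to compound 4 (0.30 log units; within the scatter) is expected in this assay. For compound 4 the estimated value is 15000 nM, with an expected range of 5000 nM to 45000 nM.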

Compound 4, half-maximal inhibitory concentration: 1100 nM
Compound 4: middle estimate off by 14-fold (1.13 log units), on the high side; measured number below the stated range.
By their numbers in this assay, from the lowest: compound 4; then compound 2; then compounds 3 and 1 (each within the scatter of the next).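

The earlier compounds shown here showed only what happens when the whole group on the core is exchanged, and the largest of those steps, a 5.3-fold lower number from compound 1 to compound 2 (0.72 log units; beyond the scatter), stayed modest in this assay. Compound 4 shows that the 1H-benzimidazol-2-yl group need not be exchanged to move the number much further: with a 27-fold lower number from compound 1 to compound 4 (1.44 log units; beyond the scatter), a single nitro in place of hydrogen on its six-membered aromatic ring of carbon only gives a large step, so this ring is a place where a small addition counts for more than any exchange of the whole group seen in this set. Nothing shown here accounts for the size of this step.

The compounds shown leave open whether the step belongs to nitro itself or to substitution at this carbon in general, as an amine, a chlorine atom or a methoxy group on the same carbon would show. They also leave open whether nitro on the 1,3-benzoxazol-2-yl of compound 2 or the 1,3-benzothiazol-2-yl of compound 3 would bring a step of similar size.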